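Exchanging the amide-bound ring: compound 2 to compound 4

The source may report more compounds than this note shows. Statements on the series, on what has been measured and on what is new or still open speak of the compounds shown alone.

Measured so far in an ADME assay on MT4 cells (Homo sapiens) for cytotoxicity, read by MTT assay; a higher number here means that more compound is tolerated, a lower number that less compound is tolerated:
compound 1 `COC(=O)c1ccc(NC(=O)CSc2nncnc2-c2ccccc2Cl)c(Br)c1` gives 59000 nM
compound 2 `Cc1ccccc1NC(=O)CSc1nncnc1-c1cccc2ccccc12` gives 158000 nM
compound 3 `CCOC(=O)c1ccc(NC(=O)CSc2nncnc2-c2ccccc2Cl)c(Br)c1` gives 69000 nM

Compound 2 has the highest number of the three, beyond the scatter from both compound 3 and compound 1. Compound 4 `O=C(CSc1nncnc1-c1cccc2ccccc12)Nc1cccnc1Cl` differs from compound 2 by a single change: 2-chloropyridin-3-yl in place of 2-methylphenyl on an amide-type nitrogen. For the measured compounds named here, the only step measured between neighbouring compounds, a 1.2-fold higher number from compound 1 to compound 3 (0.07 log units; within the scatter), concerns the chain carbon bound to an oxygen next to a carbonyl group in a different pair and lies within the scatter; it says nothing about replacing the aromatic group on the amide nitrogen. Going by the values given here, with no step bearing on this change, the expectation for this assay is no step beyond the scatter in either direction. Compound 4 is therefore estimated at 120000 nM, within 50000 nM to 300000 nM. That estimate means a step of a 1.3-fold lower number from compound 2 to compound 4 (0.12 log units; within the scatter), expected to stay within the scatter.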

Compound 4, half-maximal cytotoxic concentration: 44000 nM
Compound 4: the middle estimate sits 2.7-fold (0.44 log units) above what was measured, outside the stated range (below it).
By their numbers in this assay, from the lowest: compounds 4, 1 and 3 (each within the scatter of the next); then compound 2.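

In this assay, the group on the amide-type nitrogen proves able to move the number: 2-chloropyridin-3-yl in place of 2-methylphenyl gives a 3.6-fold lower number from compound 2 to compound 4 (0.56 log units; beyond the scatter) and so less compound is tolerated. For the compounds shown here, the earlier step concerned only a chain carbon bound to an oxygen, so this is the first view of this position. Nothing available explains this step.

The ring nitrogen and the chlorine enter together, so their shares in the step stay unseparated. Going by these compounds, a 2-methylpyridin-3-yl group on the same nitrogen would leave the methyl in place and change only the ring, and its result remains open.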